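The compounds below may be only part of what the source reports. "The series", "measured", "known", "first", "only" and "open" are said of these compounds alone.

In an ADME assay on MCF-10A cells (Homo sapiens) for inhibition, with a stated time of 48 h (a lower number here means a stronger inhibitor, a higher number a weaker inhibitor), two compounds sharing a core have been measured. Compound 1 (`O=C(Nc1ccc(C(F)(F)F)cc1)N1CCC[C@H]1c1nc(-c2ccccc2)no1`) gives > 50000 nM, which is a limit of the assay and not a number. Compound 2 (`O=C(Nc1ccc(Cl)cc1)N1CCC[C@H]1c1nc(-c2ccccc2Cl)no1`) gives > 50000 nM, which is also a limit. Both compounds therefore stand at the limit of > 50000 nM in this assay, at which 2 of the 2 values shown sit. Compound 3 (`O=C(Nc1ccc(Cl)cc1)N1CCC[C@H]1c1nc(-c2cccc(Br)c2)no1`) has 3-bromophenyl in place of 2-chlorophenyl on an aromatic carbon of the five-membered aromatic ring with 2 nitrogen and 1 oxygen (3-bromophenyl in place of 2-chlorophenyl on an aromatic carbon). For the measured compounds named here, no measured step is available to size this change in this assay, so no shift beyond the scatter, in either direction, is expected. This expectation rests on compound 2, whose only reading is the limit > 50000 nM. The estimated change is a number no higher from compound 2 to compound 3 (the limit leaves the size open). Compound 3 is expected to give 50000 nM, with an estimated range from 20000 nM to 100000 nM.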

Compound 3, half-maximal inhibitory concentration: > 50000 nM
Compound 3 gave a limit, no number; the forecaster's own chance of this, stated with the estimate: 80%; the middle value lies on the limit itself.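

Compound 2 and compound 3 both read only as a limit, so the step from 2-chlorophenyl to 3-bromophenyl cannot be read: the limit of > 50000 nM in this assay, at which 3 of the 3 values shown sit. The compounds shown leave open whether any change to the shared core would give a number rather than a limit.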